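Adding a methoxy to a compound at the limit

The source may hold more compounds than are shown below. What is called first, only, known or untested is meant among the compounds shown, and "the series" means these compounds.

In an ADME assay on HT-29 cells (Homo sapiens) for cytotoxicity, read by MTT assay, with a stated time of 72 h (on this read-out higher numbers stand for weaker inhibition and lower numbers for stronger inhibition), compound 1 (`COC(=O)c1cc(C2=C(c3cc(OC)c(OC)c(OC)c3)C(=O)CC2O[SiH2]C(C)(C)C)ccc1OC`) gives > 100 ug/mL as a limit of the assay. Compound 2 (`COc1ccc(C2=C(c3cc(OC)c(OC)c(OC)c3)C(=O)CC2O[SiH2]C(C)(C)C)cc1OC`) likewise gives > 100 ug/mL as a limit. Compound 2 thus stands without a number of its own (the limit of > 100 ug/mL in this assay, at which 2 of the 2 values shown sit). The change to compound 3 (`COCOc1cc(C2=C(c3cc(OC)c(OC)c(OC)c3)C(=O)CC2O[SiH2]C(C)(C)C)ccc1OC`) is methoxy in place of hydrogen on a saturated chain carbon bound to an oxygen on an aromatic ring and turns 3,4-dimethoxyphenyl to 4-methoxy-3-(methoxymethoxy)phenyl. Among the measured compounds shown here, only one measured step bears on this, with methoxy in place of methoxycarbonyl on an aromatic carbon (a step that the two limits leave unreadable from compound 1 to compound 2). That step has no readable size, so it offers no measured guide to the size or direction of the new change. The expected step of a number no higher from compound 2 to compound 3 (the limit leaves the size open) is therefore none beyond the scatter in this assay and has no expected direction. For compound 3 the estimated value is 100 ug/mL with an expected range from 50 ug/mL to 200 ug/mL and a report as a limit again being the likeliest outcome.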

Compound 3, half-maximal inhibitory concentration: 43 ug/mL
The estimate for compound 3 lay 2.3-fold (0.37 log units) above the measured number; the measured number lies below the stated range.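

In this assay, among the compounds shown here, the methoxy entering on a saturated chain carbon bound to an oxygen on an aromatic ring gives the first readable change: an at least 2.3-fold lower number from compound 2 to compound 3 (0.36 log units; beyond the scatter). Methoxymethoxy in place of methoxycarbonyl on an aromatic carbon reads the same way, with an at least 2.3-fold lower number from compound 1 to compound 3 (0.36 log units; beyond the scatter), and both sizes remain open, since each step starts from a limit. The step between compound 1 and compound 2 cannot be read, so only compound 3 shows that a change on this aromatic ring can bring a number within the range of the assay, while the other two stay at the limit: the limit of > 100 ug/mL in this assay, at which 2 of the 3 values shown sit.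

As far as these compounds go, whether a longer chain such as ethoxymethoxy would lower the number further remains open. From the compounds shown here alone, it is also open whether a hydroxyl or an amine on the same aromatic carbon would give a number at all.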